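Swapping the ring on the amine nitrogen of compound 2

A few compounds are considered here, and "the series" means these few. Any claim that something is new, unique, unknown or untested is made for them only; others in the source may bear on it.

Measured so far:
- compound 1, `CCCCCCCCC(C)Nc1ccc(NC(=O)c2cc(Cl)ccc2O)c(Cl)c1`, 21900 nM
- compound 2, `O=C(Nc1ccc(NC2CCCCC2)cc1Cl)c1cc(Cl)ccc1O`, 68300 nM

Of the compounds shown here, two with the same core have been tested in an ADME assay on A549 cells (Homo sapiens) for cytotoxicity, read by resazurin assay, with a stated time of 48 h; a lower number here means that less compound is tolerated, a higher number that more compound is tolerated. Compound 1 `CCCCCCCCC(C)Nc1ccc(NC(=O)c2cc(Cl)ccc2O)c(Cl)c1` gives 21900 nM. Compound 2 `O=C(Nc1ccc(NC2CCCCC2)cc1Cl)c1cc(Cl)ccc1O` gives 68300 nM, the higher of the two numbers; the gap between compound 1 and compound 2 lies beyond the scatter, so compound 2 is the better tolerated of the pair.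

Compound 3 `O=C(Nc1ccc(NCc2ccc(O)cc2)cc1Cl)c1cc(Cl)ccc1O` has not yet been measured in this assay. It differs from compound 2 in one place: 4-hydroxybenzyl in place of cyclohexyl on a nitrogen on an aromatic ring. Among the measured compounds shown here, no measured pair shows this change, so its effect must be guessed.

Compound 2 already carries a ring at this nitrogen and is tolerated well. The step from compound 2 to compound 3 is expected to be small, a 1.2-fold higher number from compound 2 to compound 3 (0.09 log units; within the scatter), with a modest move toward a higher number that may not clear the scatter. Compound 3 is therefore estimated at 85000 nM, within a range of 35000 nM to 200000 nM, and a reading at the limit of the assay is possible.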

Compound 3, half-maximal cytotoxic concentration: 116000 nM
Estimate against measurement, compound 3: 1.4-fold (0.14 log units) below, within the range that was stated.
By their numbers in this assay, from the lowest: compound 1; then compounds 2 and 3 (each within the scatter of the next).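

In this assay, among the compounds shown here, replacing cyclohexyl with 4-hydroxybenzyl on the nitrogen on the aromatic ring gives a 1.7-fold higher number from compound 2 to compound 3 (0.23 log units; within the scatter), so this exchange produces no step that clears the scatter. This position therefore carries either a six-membered non-aromatic ring of carbon only or a six-membered aromatic ring with little to separate the two readings, even though the entering group adds a hydrogen-bond donor and a hydrogen-bond acceptor that the leaving group lacks. No measurement is available that would explain this outcome.

The single exchange alters the ring and adds the hydroxyl at once, so the compounds shown cannot assign any part of the step to either feature, and a plain benzyl or a 4-methoxybenzyl group on this nitrogen would be needed to separate them. From the compounds shown here alone, how far this tolerance extends also remains open, since the set holds no amine or carboxylic acid on the benzyl ring, and such groups could show whether this position stays as undemanding in this assay.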